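Quinolinyl dienone series: notes ahead of compound 4

This account rests on a few compounds, and the source may have more. Where it says the series, first, only, none or still open, it means among the compounds named here.

Compound 1 `COc1ccc(/C=C/C(=O)/C=C/c2cc3ccccc3nc2Oc2ccccc2)cc1` in a functional assay on PC-3 cells (Homo sapiens) for cytotoxicity, read by MTT assay, with a stated time of 48 h (a lower number here means a stronger inhibitor, a higher number a weaker inhibitor), gives > 10000 nM, a limit of the assay.
Compound 2 `COc1ccc(/C=C/C(=O)/C=C/c2cc3ccccc3nc2Oc2ccccc2)cc1OC` in this assay gives > 10000 nM, also a limit.
Compound 3 `COc1ccc(/C=C/C(=O)/C=C/c2cc3ccccc3nc2Oc2ccc(Br)cc2)cc1` in this assay gives > 10000 nM, again a limit.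

Within the data shown here, all three values sit at the limit (the limit of > 10000 nM in this assay, at which 3 of the 3 values shown sit), so no step in the set can be sized. The change methoxy in place of hydrogen on an aromatic carbon gives a step that the two limits leave unreadable from compound 1 to compound 2. The change bromo in place of hydrogen on an aromatic carbon gives a step that the two limits leave unreadable from compound 1 to compound 3.

Compound 4 `COc1ccc(/C=C/C(=O)/C=C/c2cc3ccccc3nc2Oc2ccc(Br)cc2)c(OC)c1` is unmeasured. It differs from compound 3 by methoxy in place of hydrogen on an aromatic carbon. This is the same kind of change as from compound 1 to compound 2, though the surroundings differ: in compound 2 the entering methoxy is ortho to a methoxy group and meta to a large group, whereas in compound 4 it is ortho to a large group and meta to a methoxy group. The two cores differ by bromo in place of hydrogen on an aromatic carbon.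

With compound 3 at > 10000 nM and nothing in the set read as a number, the step from compound 3 to compound 4 is expected to be a step that the limit leaves unreadable from compound 3 to compound 4. Compound 4 is therefore estimated at 15000 nM in this assay, within 4000 nM to 60000 nM, most likely reported once more only as a limit.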

Compound 4, half-maximal inhibitory concentration: > 10000 nM
Compound 4 gave a limit, no number (the forecaster's own chance of this, stated with the estimate: 75%); the middle value does not contradict the limit.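

In this assay compound 4 gives > 10000 nM, a limit, so no new step can be read between compound 3 and compound 4: the limit of > 10000 nM in this assay, at which 4 of the 4 values shown sit.

The compounds shown leave open where any of compounds 1 to 4 would fall as a number, and whether methoxy or bromo in place of hydrogen shifts the read-out at all.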